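Amide nitrogen substituent change in the quinoline ether amide series

The compounds below may be only part of what the source reports. "The series", "measured", "known", "first", "only" and "open" are said of these compounds alone.

Three compounds have numbers in a physicochemical assay for lipophilicity, read by HPLC, in phosphate buffer, measured as chromatographic lipophilicity, at pH 7.4; a higher number here means a more lipophilic compound, a lower number a more polar compound. Compound 1 `Cc1cc(C)cc(NC(=O)COc2cc(C)nc3ccc(C(F)(F)F)cc23)c1` gives 6.67, compound 2 `COc1ccc2nc(C(F)(F)F)cc(OCC(=O)Nc3cc(C)cc(C)c3)c2c1` gives 7.02, and compound 3 `COc1ccc2nc(C)cc(OCC(=O)NCc3cc(C)cc(C)c3)c2c1` gives 5.25. Compound 3 stands lowest of the three: compound 1 is the nearest to it, at a number well beyond the scatter above it, and compound 2 lies furthest, further still above. For the measured compounds named here, no single-change pairs exist among the measured compounds, so no step can be read directly from them.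

Compound 4 `COc1ccc2nc(C)cc(OCC(=O)Nc3cc(F)cc(F)c3)c2c1` differs from compound 3 in one place: 3,5-difluorophenyl in place of 3,5-dimethylbenzyl on an amide-type nitrogen. Compounds 1 and 2 both carry a phenyl group, not a benzyl group, on the amide nitrogen and both sit well above compound 3 in this assay, which is the only point of reference for this kind of change; they also differ from compound 3 elsewhere, so the comparison is loose. The step is expected to be upward and of moderate size, estimated as a number 0.65 log units higher from compound 3 to compound 4 (beyond the scatter), beyond the scatter. Compound 4 is accordingly expected at about 5.9, within a range of 5.2 to 6.6.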

Compound 4, distribution coefficient: 5.13
Beside the measured number, compound 4's estimate is 0.77 log units above it; the whole stated range lies above it.
By their numbers in this assay, from the lowest: compounds 4 and 3 (each within the scatter of the next); then compound 1; then compound 2.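

In this assay, 3,5-difluorophenyl in place of 3,5-dimethylbenzyl on an amide-type nitrogen gives a number 0.12 log units lower from compound 3 to compound 4 (within the scatter), so the two compounds cannot be told apart on this read-out. For the compounds shown here, this is the first step that can be read at a single position, and it shows that this particular exchange of groups on the amide-type nitrogen, with the rest of the structure held constant, leaves no measurable difference. Nothing available explains this result.

The exchange alters the benzyl-versus-phenyl attachment and the methyl-versus-fluorine ring substituents together, so the separate contribution of each cannot be read, and two opposing contributions cannot be told from none at all. A 3,5-difluorobenzyl group on this nitrogen, with the rest of compound 3 kept, would separate the two.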